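One Methyl, Repeated Twice: Cytotoxicity in a Matched Series

The compounds below may be only part of what the source reports. "The series", "measured", "known", "first", "only" and "open" are said of these compounds alone.

Measured compounds:
compound 1 `O=C1/C(=C/c2cccnc2)CN(S(=O)(=O)c2ccccc2)C/C1=C\c1ccccc1C(F)(F)F` — 12500 nM
compound 2 `Cc1ccc(S(=O)(=O)N2C/C(=C\c3cccnc3)C(=O)/C(=C/c3ccccc3C(F)(F)F)C2)cc1` — 12300 nM
compound 3 `O=C1/C(=C/c2ccncc2)CN(S(=O)(=O)c2ccccc2)C/C1=C\c1ccccc1C(F)(F)F` — 12300 nM

Three compounds were tested in an ADME assay on L02 cells (Homo sapiens) for cytotoxicity, read by MTT assay, with a stated time of 24 h; on this read-out higher numbers stand for weaker inhibition and lower numbers for stronger inhibition. In this assay compound 1 gives 12500 nM, compound 2 gives 12300 nM and compound 3 gives 12300 nM; all three stand within the scatter of each other, so none can be set apart from the others.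

Compound 2 differs from compound 1 by methyl in place of hydrogen on an aromatic carbon. This change gave a 1.0-fold lower number from compound 1 to compound 2 (0.01 log units; within the scatter). Compound 3 differs from compound 1 in its core, by pyridin-4-yl in place of pyridin-3-yl on a double-bonded chain carbon bound to a double-bonded ring carbon, and that change gave a 1.0-fold lower number from compound 1 to compound 3 (0.01 log units; within the scatter).

Compound 4 `Cc1ccc(S(=O)(=O)N2C/C(=C\c3ccncc3)C(=O)/C(=C/c3ccccc3C(F)(F)F)C2)cc1` has not yet been measured. It differs from compound 3 by methyl in place of hydrogen on an aromatic carbon. Within the data shown here, this is the same change as the one from compound 1 to compound 2: the place described for both is the same, an aromatic carbon of a six-membered aromatic ring of carbon only, para to a large group. The only difference is the core, which in compound 3 and compound 4 carries pyridin-4-yl where compound 1 and compound 2 carry pyridin-3-yl.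

Because a 1.0-fold lower number from compound 1 to compound 2 (0.01 log units; within the scatter) lay within the scatter, and because a 1.0-fold lower number from compound 1 to compound 3 (0.01 log units; within the scatter) also lay within the scatter, the expected step for compound 4 is no change at the digits printed from compound 3 to compound 4 (within the scatter). Compound 4 is estimated at 12300 nM in this assay, with an expected range from 6500 nM to 23000 nM. This expectation rests on two measured steps only, and a single series gives no further support.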

Compound 4, half-maximal inhibitory concentration: 12800 nM
Compound 4: middle estimate off by 1.0-fold (0.02 log units), on the low side; the range from low to high includes it.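

In this assay the methyl change gave a 1.0-fold higher number from compound 3 to compound 4 (0.02 log units; within the scatter), and set beside the same change on the other core it showed no difference that could be told from the scatter: the same change on two cores in this assay, a 1.0-fold lower number (0.01 log units; within the scatter) from compound 1 to compound 2 and a 1.0-fold higher number (0.02 log units; within the scatter) from compound 3 to compound 4, 1.1-fold (0.02 log units) apart, within the scatter of two such steps. The exchange of pyridin-3-yl for pyridin-4-yl gave a 1.0-fold higher number from compound 2 to compound 4 (0.02 log units; within the scatter), and it likewise read the same whether the compound carried phenylsulfonyl or (4-methylphenyl)sulfonyl: the same change on two cores in this assay, a 1.0-fold lower number (0.01 log units; within the scatter) from compound 1 to compound 3 and a 1.0-fold higher number (0.02 log units; within the scatter) from compound 2 to compound 4, 1.1-fold (0.02 log units) apart, within the scatter of two such steps. This shows that neither step lies beyond the scatter on either core, so what carried over between cores in this series was the absence of a measurable step; it does not show that a change with a real effect would carry over in the same way, and it says nothing outside this one cell read-out.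

The compounds shown leave open whether a group other than methyl at the same place, such as a methoxy group, a chlorine atom or an amine, would give a step beyond the scatter in this assay. They also leave open what a nitrile or a carboxylic acid in place of trifluoromethyl would do, and whether any such step would hold on both cores.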